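This account rests on a few compounds, and the source may have more. Where it says the series, first, only, none or still open, it means among the compounds named here.

Compound 1 `CS/C(=N\C(=O)c1csc([N+](=O)[O-])c1)NC(=O)c1csc([N+](=O)[O-])c1` carries a methylsulfanyl group on a carbon with a double bond to nitrogen. In a functional assay on PC-3 cells (Homo sapiens) for cytotoxicity, read by MTT assay, with a stated time of 72 h (a higher number here means a weaker inhibitor of growth, a lower number a stronger inhibitor of growth), compound 1 gives 41500 nM. Compound 3 `O=C(/N=C(/NC(=O)c1csc([N+](=O)[O-])c1)[Se]Cc1ccccc1)c1csc([N+](=O)[O-])c1` differs from it by a group of 8 heavy atoms (7 carbon, 1 selenium; one six-membered aromatic ring of carbon only) in place of a group of 2 heavy atoms (1 carbon, 1 sulfur; no ring), on a carbon with a double bond to nitrogen and in this assay compound 3 gives 35900 nM, so that the change amounts to a 1.2-fold lower number from compound 1 to compound 3 (0.06 log units; within the scatter).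

Compound 2 `CS/C(=N\C(=O)c1cc2ccccc2s1)NC(=O)c1cc2ccccc2s1` is built on a different core; how its core differs from that of compound 1 is not broken down here. In this assay compound 2 gives 8580 nM, the lowest number of the three measured, with both compound 1 and compound 3 standing beyond the scatter above it.

Compound 4 `O=C(/N=C(/NC(=O)c1cc2ccccc2s1)[Se]Cc1ccccc1)c1cc2ccccc2s1` has not been measured. It relates to compound 2 through (a group of 8 heavy atoms (7 carbon, 1 selenium; one six-membered aromatic ring of carbon only) in place of a group of 2 heavy atoms (1 carbon, 1 sulfur; no ring), on a carbon with a double bond to nitrogen), the same change that was made from compound 1 to compound 3, at a place described in identical words. Since that earlier change produced only a 1.2-fold lower number from compound 1 to compound 3 (0.06 log units; within the scatter), the step from compound 2 to compound 4 is expected to be of similar size, about a 1.2-fold lower number from compound 2 to compound 4 (0.07 log units; within the scatter). Compound 4 is therefore estimated at 7300 nM in this assay, most likely between 3000 nM and 18000 nM.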

Compound 4, concentration for 50% growth inhibition: 30500 nM
Estimate against measurement, compound 4: 4.2-fold (0.62 log units) below; measured number above the stated range.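

On the core of compound 2, exchanging the methylsulfanyl group for the selenium-bearing group with its six-membered aromatic ring gives a 3.6-fold higher number from compound 2 to compound 4 (0.55 log units; beyond the scatter) in this assay. Set beside the earlier step, the same change does not carry over from one core to the other at a constant size: the same change on two cores in this assay, a 1.2-fold lower number (0.06 log units; within the scatter) from compound 1 to compound 3 and a 3.6-fold higher number (0.55 log units; beyond the scatter) from compound 2 to compound 4, 4.1-fold (0.61 log units) apart, beyond the scatter of two such steps This shows that, for these two pairs, the outcome of the change depends on the core it is made on, but two pairs give no general rule for the series and do not show why the cores part ways.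

The compounds shown leave open whether the selenium atom or the aromatic ring accounts for the step on the core of compound 2, since the two enter together; a methylselanyl group, or a benzylsulfanyl group, would stand between the two ends of the change. They also leave open how the change would run on a third core, for instance one carrying an amine or a carboxylic acid.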